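This account rests on a few compounds, and the source may have more. Where it says the series, first, only, none or still open, it means among the compounds named here.

Measured compounds:
Compound 1 `O=C1Nc2ccccc2/C1=C/c1ccc(-c2cn(-c3ccc(F)cc3)nn2)cc1`: 14700 nM
Compound 2 `O=C1Nc2ccccc2/C1=C/c1ccc(-c2cn(-c3ccccc3Cl)nn2)cc1`: > 20000 nM
Compound 3 `N#Cc1ccccc1-n1cc(-c2ccc(/C=C3\C(=O)Nc4ccccc43)cc2)nn1`: 19700 nM

In an ADME assay on HUVEC cells (Homo sapiens) for inhibition, read by CCK-8 assay, with a stated time of 24 h, in the presence of a further agent that is not named here (on this read-out higher numbers stand for weaker inhibition and lower numbers for stronger inhibition), compound 2 gives > 20000 nM, which is a limit of the assay and not a number. This is the limit of > 20000 nM in this assay, at which 1 of the 3 values shown sits. Compound 1 gives 14700 nM and compound 3 gives 19700 nM, so these two carry actual numbers.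

Compound 4 `O=C1Nc2ccc(F)cc2/C1=C/c1ccc(-c2cn(-c3ccccc3Cl)nn2)cc1` differs from compound 2 in one place, fluoro in place of hydrogen on an aromatic carbon of the shared core. Within the data shown here, no measured step alters that ring. The three steps at hand all change the aryl group on an aromatic nitrogen, or the group on it, and so bear on the new change only indirectly. They are an at least 1.3-fold higher number from compound 1 to compound 2 (0.13 log units; that floor lies within the scatter), a 1.3-fold higher number from compound 1 to compound 3 (0.13 log units; within the scatter) and an at least 1.0-fold lower number from compound 2 to compound 3 (0.00 log units; that floor lies within the scatter). With only these steps as a guide, no step beyond the scatter is expected in this assay, and no direction can be favoured. The step expected is an at least 1.0-fold lower number from compound 2 to compound 4 (0.02 log units; that floor lies within the scatter). A result reported only as a limit would be no surprise.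

Compound 4 is estimated at 19000 nM, with an expected range from 9000 nM to 35000 nM.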

Compound 4, half-maximal inhibitory concentration: 18200 nM
For compound 4 the middle estimate is 1.0-fold (0.02 log units) above the measured one; the measured number falls inside the stated range.
By their numbers in this assay, from the lowest: compounds 1, 4 and 3 (each within the scatter of the next). At a limit, above all of these: compound 2.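

In this assay, compound 4 is the only compound shown whose change lies on the shared core and not on the aryl group carried by the aromatic nitrogen, and fluoro in place of hydrogen on that six-membered aromatic ring of carbon only gives an at least 1.0-fold lower number from compound 2 to compound 4 (0.04 log units; that floor lies within the scatter). Compound 2 stands at > 20000 nM, which is a limit of the assay and not a number. On these data alone, with this change the 2-chlorophenyl series gains an actual number in compound 4, yet the true size of the step stays unknown, because one end of it is only a limit: the limit of > 20000 nM in this assay, at which 1 of the 4 values shown sits.

As far as these compounds go, it remains open whether fluoro on this ring would give a step beyond the scatter with 4-fluorophenyl or 2-cyanophenyl on the aromatic nitrogen, where the starting compounds carry actual numbers. From the compounds shown here alone, it is also open whether a different group at this position, such as methoxy, an amine or a carboxylic acid, would separate from the hydrogen compound in this assay.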